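Urea Tail Variation in a Sulfonamide Oxadiazole Series

The source may hold more compounds than are shown below. What is called first, only, known or untested is meant among the compounds shown, and "the series" means these compounds.

Measured compounds:
compound 1, `Cc1ccc(S(=O)(=O)Nc2cccc(-c3nc(-c4ccc(NC(=O)c5cccnc5)cc4Cl)no3)c2)cc1` — > 10000 nM (a limit, not a number)
compound 2, `CCNC(=O)Nc1ccc(S(=O)(=O)Nc2cccc(-c3nc(-c4ccc(NC(=O)c5cccnc5)cc4Cl)no3)c2)cc1` — 3100 nM

Within the data shown here, in a functional assay on MDA-MB-231 cells (Homo sapiens) for antiproliferative activity, read by MTT assay, with a stated time of 72 h (on this read-out lower numbers stand for stronger inhibition and higher numbers for weaker inhibition), compound 2 gives 3100 nM, the only actual number among the two values shown. Compound 1 reaches only the limit of > 10000 nM in this assay. Among the measured compounds shown here, the one measured step, an at least 3.2-fold lower number from compound 1 to compound 2 (0.50 log units; beyond the scatter), is therefore an open-ended comparison against the limit of > 10000 nM in this assay, at which 1 of the 2 values shown sits, rather than a difference between two numbers.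

Compound 3, `O=C(Nc1ccc(-c2noc(-c3cccc(NS(=O)(=O)c4ccc(NC(=O)N5CCCCC5)cc4)c3)n2)c(Cl)c1)c1cccnc1`, keeps the urea-bearing sulfonamide of compound 2 but alters its outer end: piperidin-1-yl in place of ethylamino on a carbonyl carbon. For the measured compounds named here, the only measured step, from compound 1 to compound 2, concerns the introduction of the whole (ethylcarbamoyl)amino group in place of methyl, not a change within an existing urea, so it bears on this step only loosely. Nothing in the two values shown says whether the ethylamino end matters once the urea is present. The step from compound 2 to compound 3 is therefore expected to stay within the scatter, a 1.0-fold higher number from compound 2 to compound 3 (0.01 log units; within the scatter), and compound 3 is estimated at 3200 nM, within 1000 nM to 10000 nM.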

Compound 3, half-maximal inhibitory concentration: > 10000 nM
Compound 3: only a limit was reported; the forecaster's own chance of this, stated with the estimate: 20%; middle value at least 3.1-fold (0.49 log units) away from the limit.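

In this assay, the outer end of the urea proves not to be a free position: piperidin-1-yl in place of ethylamino on a carbonyl carbon gives an at least 3.2-fold higher number from compound 2 to compound 3 (0.50 log units; beyond the scatter), so the gain seen on adding the urea does not survive this change. The exchange replaces ethylamino, with 1 hydrogen-bond donor and no ring, by piperidin-1-yl, with 0 hydrogen-bond donors and one six-membered non-aromatic ring, and this single pair cannot separate those two differences. The size of the loss is open-ended and the step between compound 1 and compound 3 cannot be read, the value of each being a limit: the limit of > 10000 nM in this assay, at which 2 of the 3 values shown sit.

The compounds shown leave open whether the loss follows from the missing hydrogen on the urea nitrogen or from the ring itself; a dimethylamino end would carry no such hydrogen and no ring, while a cyclohexylamino end would carry both. They also leave open whether a longer chain such as n-butylamino, or a smaller one such as methylamino, on the same carbonyl carbon would move the number in either direction from that of compound 2.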